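A few compounds are considered here, and "the series" means these few. Any claim that something is new, unique, unknown or untested is made for them only; others in the source may bear on it.

Compounds 1, 2 and 3 share one core and differ at a single aromatic carbon. Compound 1 `Nc1ccc(-c2cc(=O)c3c(N)c(F)c(Br)c(F)c3o2)cc1F` carries bromo there and in a functional assay on MCF7 cells (Homo sapiens) for cytotoxicity, read by neutral red uptake, with a stated time of 3 days (a lower number here means a stronger inhibitor, a higher number a weaker inhibitor), compound 1 gives 160 nM. Compound 2 `Nc1ccc(-c2cc(=O)c3c(N)c(F)c(Cl)c(F)c3o2)cc1F` carries chloro, and in this assay compound 2 gives 210 nM; the step of a 1.3-fold higher number from compound 1 to compound 2 (0.12 log units; within the scatter) lies within the scatter. Compound 3 `Nc1ccc(-c2cc(=O)c3c(N)c(F)c(C(=O)O)c(F)c3o2)cc1F` carries carboxy. In this assay compound 3 reaches only a limit of the assay, > 10000 nM. On these data alone, its value sits at the limit of > 10000 nM in this assay, at which 1 of the 3 values shown sits, so the steps of an at least 62-fold higher number from compound 1 to compound 3 (1.79 log units; beyond the scatter) and an at least 47-fold higher number from compound 2 to compound 3 (1.67 log units; beyond the scatter) are both large, and their true size is unknown.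

Compound 4 `COCc1c(F)c(N)c2c(=O)cc(-c3ccc(N)c(F)c3)oc2c1F` has not yet been measured. It differs from compound 3 by methoxymethyl in place of carboxy on an aromatic carbon. The two steps that reach compound 3 show that carboxy at this carbon gives a far higher number than either halogen; methoxymethyl removes carboxy, so for compound 4 a large downward step is expected, an at least 10-fold lower number from compound 3 to compound 4 (1.00 log units; beyond the scatter), though the data do not show whether it returns fully to the level of the halogen compounds. Compound 4 is therefore estimated at 1000 nM in this assay, expected to fall between 200 nM and 8000 nM.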

Compound 4, half-maximal inhibitory concentration: 46 nM
For compound 4 the middle estimate is 22-fold (1.34 log units) above the measured one; the measured number lies below the stated range.
By their numbers in this assay, from the lowest: compound 4; then compounds 1 and 2 (each within the scatter of the next). At a limit, above all of these: compound 3.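

In this assay, on these data alone, methoxymethyl gives an at least 210-fold lower number from compound 3 to compound 4 (2.33 log units; beyond the scatter), a step whose true size stays unknown: the limit of > 10000 nM in this assay, at which 1 of the 4 values shown sits. More informative are the steps from the halogens, a 4.6-fold lower number from compound 2 to compound 4 (0.66 log units; beyond the scatter) and a 3.5-fold lower number from compound 1 to compound 4 (0.54 log units; beyond the scatter), which show that this carbon accepts more than bromo or chloro and that, among the four compounds, methoxymethyl gives the lowest number. Carboxy and methoxymethyl both bring 3 heavy atoms and 1 hydrogen-bond acceptor, yet they give the two most distant results, so those counts alone do not set the outcome at this carbon.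

As far as these compounds go, whether the oxygen of methoxymethyl contributes remains open, and an ethyl or a longer ether chain would bear on that. From the compounds shown here alone, it is also open whether the high number for carboxy follows its hydrogen-bond donor, which a hydroxymethyl or a methyl ester would help to separate.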